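The source may report more compounds than this note shows. Statements on the series, on what has been measured and on what is new or still open speak of the compounds shown alone.

Measured so far:
- compound 1 `C/C(COc1cccc2ccccc12)=N\O`: > 50000 nM
- compound 2 `O/N=C(\COc1cccc2ccccc12)c1ccc(Cl)cc1`: > 50000 nM
- compound 3 `O/N=C(\COc1cccc2ccccc12)c1ccc(Br)cc1`: > 50000 nM

In an ADME assay on NPC-TW01 cells (Homo sapiens) for cytotoxicity, read by MTT assay (a higher number here means a weaker inhibitor, a lower number a stronger inhibitor), compound 3 gives > 50000 nM, which is a limit and not a number. The other two entries are limits as well, so the whole set stands at the limit of > 50000 nM in this assay, at which 3 of the 3 values shown sit.

The next compound, compound 4 `O/N=C(\COc1cccc2ccccc12)c1ccc(C(F)(F)F)cc1`, carries trifluoromethyl in place of bromo on an aromatic carbon, para to a large group: trifluoromethyl in place of bromo on an aromatic carbon.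

Among the measured compounds shown here, only one measured step changes a single place, bromo in place of chloro on an aromatic carbon. It is a step that the two limits leave unreadable from compound 2 to compound 3, so it offers no size to carry forward. Since compound 3 and its relatives all sit at the limit of > 50000 nM in this assay, at which 3 of the 3 values shown sit, no shift beyond the scatter is expected in this assay, in either direction. The expected change is a number no higher from compound 3 to compound 4 (the limit leaves the size open). For compound 4 the estimate is 50000 nM, with an expected range of 20000 nM to 50000 nM, and a report of only a limit is the likeliest outcome.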

Compound 4, half-maximal inhibitory concentration: 46400 nM
Compound 4: the middle estimate sits 1.1-fold (0.03 log units) above what was measured; low and high end bracket the measured number.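

In this assay compound 4 gives 46400 nM and is the only compound shown whose value is a number and not a limit. Going by these compounds, on this aromatic carbon, para to a large group, the two swaps give an at least 1.0-fold lower number from compound 3 to compound 4 (0.03 log units; that floor lies within the scatter) and an at least 1.0-fold lower number from compound 2 to compound 4 (0.03 log units; that floor lies within the scatter) and each of these is only a floor, so the true size of the change stays open. The step between compound 2 and compound 3 cannot be read, and most of the set stays at one ceiling: the limit of > 50000 nM in this assay, at which 3 of the 4 values shown sit.

On these data alone, what remains open is how a very different group on this carbon, such as an amine or a carboxylic acid, would read in this assay and whether it would leave that ceiling. As far as these compounds go, the actual numbers behind the limits of compound 2 and compound 3 also stay unknown, so the real distance from either one to compound 4 cannot be stated.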